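Replacing 2,4,6-trihydroxyphenyl with 4-bromophenyl in compound 2

The source may hold more compounds than are shown below. What is called first, only, known or untested is meant among the compounds shown, and "the series" means these compounds.

Measured in a functional assay on DU-145 cells (Homo sapiens) for inhibition, read by trypan blue exclusion, with a stated time of 96 h; on this read-out higher numbers stand for weaker inhibition of growth and lower numbers for stronger inhibition of growth:
- Compound 1 `O=C(/C(=C\c1c(O)cc(O)cc1O)S(=O)(=O)c1ccccc1Br)c1ccc(Br)cc1`: 50000 nM
- Compound 2 `Cc1ccc(S(=O)(=O)/C(=C/c2c(O)cc(O)cc2O)C(=O)c2ccc(Br)cc2)cc1`: > 100000 nM, a limit of the assay
- Compound 3 `O=C(/C(=C/c1ccc(Cl)cc1)Cc1ccc(Cl)cc1)c1ccc(Cl)cc1Cl`: 10000 nM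

Compound 2 yields no number, only a limit: it stands at the limit of > 100000 nM in this assay, at which 1 of the 3 values shown sits. The account now turns to compound 4 `Cc1ccc(S(=O)(=O)/C(=C/c2ccc(Br)cc2)C(=O)c2ccc(Br)cc2)cc1`, which differs from compound 2 as follows: 4-bromophenyl in place of 2,4,6-trihydroxyphenyl on a double-bonded chain carbon bound to a double-bonded chain carbon. The new group is 4-bromophenyl, on a double-bonded chain carbon bound to a double-bonded chain carbon.

Going by the values given here, no measured step covers this change directly. The only one, an at least 2.0-fold higher number from compound 1 to compound 2 (0.30 log units; that floor lies within the scatter), puts 4-methylphenyl in place of 2-bromophenyl on a sulfonyl sulfur, a different place, so it says little about the size to expect here. Compound 3 also lacks the 2,4,6-trihydroxyphenyl and gives 10000 nM in this assay, although it differs in other places too. On that slender ground, a move toward lower numbers, meaning stronger inhibition of growth, is expected, and its size remains uncertain. The expected move is an at least 3.3-fold lower number from compound 2 to compound 4 (0.52 log units; beyond the scatter). For compound 4 the estimated value is 30000 nM, with an expected range of 5000 nM to 100000 nM.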

Compound 4, concentration for 50% growth inhibition: 10000 nM
Compound 4: the middle estimate sits 3.0-fold (0.48 log units) above what was measured, and the stated range covers the measured number.
By their numbers in this assay, from the lowest: compounds 3 and 4 (each within the scatter of the next); then compound 1. At a limit, above all of these: compound 2.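

In this assay, putting 4-bromophenyl in place of 2,4,6-trihydroxyphenyl on a double-bonded chain carbon bound to a double-bonded chain carbon gives an at least 10-fold lower number from compound 2 to compound 4 (1.00 log units; beyond the scatter), toward stronger inhibition of growth. The earlier step on the sulfonyl sulfur had a floor that lay within the scatter, so this is the first change among these compounds whose size clearly clears it, and it marks this position as one where the group matters to the read-out. Compound 2 gives a limit and not a number, so this step is only a floor and its full size stays unread: the limit of > 100000 nM in this assay, at which 1 of the 4 values shown sits.

The compounds shown leave open whether the shift follows the bromine that enters or the loss of the hydroxyl groups of 2,4,6-trihydroxyphenyl, and what a plain phenyl, a 4-methoxyphenyl or a 4-aminophenyl would give at this place. They also leave open whether the same swap would carry the same weight with 2-bromophenyl on the sulfonyl sulfur, as in compound 1.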